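The source may report more compounds than this note shows. Statements on the series, on what has been measured and on what is new or still open speak of the compounds shown alone.

In a functional assay on NCI-H1975 cells (Homo sapiens) for cytotoxicity, read by MTT assay, with a stated time of 72 h (on this read-out lower numbers stand for stronger inhibition and higher numbers for weaker inhibition), the measured compounds read:
- compound 1 `CN1CCN(c2ccc(Nc3ncc4nc(Nc5cccc([N+](=O)[O-])c5)n(C5CCCC5)c4n3)cc2)CC1` gives 980 nM
- compound 2 `Cc1cccc(Nc2nc3cnc(Nc4ccc(N5CCN(C)CC5)cc4)nc3n2C2CCCC2)c1` gives 560 nM
- compound 3 `CN1CCN(c2ccc(Nc3ncc4nc(Nc5cccc(Cl)c5)n(C5CCCC5)c4n3)cc2)CC1` gives 390 nM

Going by the values given here, one gap is beyond the scatter (a 2.5-fold lower number from compound 1 to compound 3 (0.40 log units; beyond the scatter)) and one lies within it (a 1.4-fold lower number from compound 2 to compound 3 (0.16 log units; within the scatter)), so compound 3 is separated from only one of its two neighbours. Compound 4 `CN1CCN(c2ccc(Nc3ncc4nc(Nc5cccc(NC(=O)c6ccccc6)c5)n(C5CCCC5)c4n3)cc2)CC1` has benzamido in place of chloro on an aromatic carbon. The nearest evidence is the swaps among nitro, methyl and chloro on this carbon. The largest was modest (a 2.5-fold lower number from compound 1 to compound 3 (0.40 log units; beyond the scatter)) and another stayed within the scatter (a 1.8-fold lower number from compound 1 to compound 2 (0.24 log units; within the scatter)). None of these groups holds a ring, so these steps guide only loosely. A modest rise in the number is expected in this assay (a 2.1-fold higher number from compound 3 to compound 4 (0.31 log units; beyond the scatter)). Compound 4 is estimated at 800 nM (range 250 nM to 3000 nM).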

Compound 4, half-maximal inhibitory concentration: 2120 nM
Estimate against measurement, compound 4: 2.7-fold (0.42 log units) below; measured number inside the range.
By their numbers in this assay, from the lowest: compounds 3, 2 and 1 (each within the scatter of the next, the first and the last beyond it); then compound 4.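

In this assay, going by these compounds alone, benzamido, the only group at this aromatic carbon that holds a ring, gives the highest number of the series, and each step to it lies beyond the scatter (a 5.4-fold higher number from compound 3 to compound 4 (0.74 log units; beyond the scatter); a 3.8-fold higher number from compound 2 to compound 4 (0.58 log units; beyond the scatter); a 2.2-fold higher number from compound 1 to compound 4 (0.34 log units; beyond the scatter)). All three ring-free groups, nitro, methyl and chloro, therefore read lower than benzamido at this position. Nothing shown accounts for this rise. As far as these compounds go, what remains open is whether the rise goes with the added ring or with the amide link. Acetamido or phenyl on this carbon would separate the two.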